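Swapping a Hydroxy Side Chain for a Pyrazole Amide

This account rests on a few compounds, and the source may have more. Where it says the series, first, only, none or still open, it means among the compounds named here.

Of the compounds shown here, three have been measured in an assay on cells for positive allosteric modulation of Cystic fibrosis transmembrane conductance regulator variant G551D (Homo sapiens), with stated times of 10 min and 2 min, in the presence of a further agent that is not named here; on this read-out higher numbers stand for an effect only at larger amounts of compound and lower numbers for an effect already at smaller amounts. Compound 1 `CC1(C)Cc2c(sc(NC(=O)c3ccccc3O)c2C(N)=O)CO1` gives 490 nM, compound 2 `CC1Cc2c(sc(NC(=O)c3ccccc3O)c2C(N)=O)C(C)O1` gives 236 nM, and compound 3 `CC1(C)Cc2c(sc(NC(=O)[C@@H](O)C(C)(C)C)c2C(N)=O)C(C)(C)O1` gives 421 nM. Compound 3 therefore sits between the other two, nearest to compound 1 and furthest from compound 2, yet both gaps fall within the usual scatter of repeated measurements, so the three cannot be told apart on these numbers.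

Compound 4 `Cc1cc(C(=O)Nc2sc3c(c2C(N)=O)CC(C)(C)OC3(C)C)[nH]n1` differs from compound 3 in one place: 3-methyl-1H-pyrazol-5-yl in place of 1-hydroxy-2,2-dimethylpropyl on a carbonyl carbon. Among the compounds with values here, no measured pair changes this position, so there is no direct step to lean on. What the data do show is that a ring-bearing amide is tolerated here, since compound 1 at 490 nM and compound 2 at 236 nM land close to compound 3 at 421 nM.

The step from compound 3 to compound 4 is thus expected to be small, a 1.2-fold lower number from compound 3 to compound 4 (0.08 log units; within the scatter), with no clear direction beyond the scatter. Compound 4 is expected to give about 350 nM, with a likely range from 120 nM to 1000 nM.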

Compound 4, half-maximal effective concentration: 590 nM
The estimate for compound 4 lay 1.7-fold (0.23 log units) below the measured number, and the stated range covers the measured number.
By their numbers in this assay, from the lowest: compounds 2, 3, 1 and 4 (each within the scatter of the next, the first and the last beyond it).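

On the shared core, this position accepts the 3-methyl-1H-pyrazol-5-yl group on the carbonyl carbon in place of the 1-hydroxy-2,2-dimethylpropyl group, and the outcome in this assay is a 1.4-fold higher number from compound 3 to compound 4 (0.15 log units; within the scatter). Compound 3 and compound 4 therefore cannot be told apart, even though this single change swaps an open chain for a five-membered aromatic ring and removes the defined stereocentre. No measured information here explains the result.

This one pair cannot show whether other groups on the same carbonyl carbon would also leave the number within the scatter, such as a primary amine on a short chain, a carboxylic acid or a longer alkyl chain. It also leaves open whether the 3-methyl group on the pyrazole matters, which the unsubstituted 1H-pyrazol-5-yl group could test.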